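The source may report more compounds than this note shows. Statements on the series, on what has been measured and on what is new or still open speak of the compounds shown alone.

Working notes on the series. Among the compounds with values here, in an ADME assay on CHO cells (Cricetulus griseus) for cytotoxicity, read by LDH release (a higher number here means a weaker inhibitor, a lower number a stronger inhibitor), compound 2 `CC(Oc1ccc(Cl)cc1Cl)C(=O)NCc1ccccc1F` gives 47000 nM, the only true number available so far. Compound 1 `CC(Oc1ccc(Cl)cc1Cl)C(=O)NC(c1ccc(F)cc1)C(C)C` reads > 100000 nM, which is a limit of the assay and not a number. Compound 2 therefore serves as the sole numerical reference point.

The next comparison is with compound 3 `Cc1ccccc1CNC(=O)C(C)Oc1ccc(Cl)cc1Cl`, which has not yet been measured. The structural change is methyl in place of fluoro on an aromatic carbon, ortho to a large group. The rest of the structure is shared with compound 2.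

Within the data shown here, no measured pair shows a change of this kind, so the expectation rests on compound 2 at 47000 nM alone. No step beyond the scatter is expected, in either direction. The expected change is a 1.1-fold higher number from compound 2 to compound 3 (0.03 log units; within the scatter). For compound 3 the estimated value is 50000 nM, with an expected range of 20000 nM to 100000 nM.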

Compound 3, half-maximal inhibitory concentration: > 100000 nM
Compound 3: a limit, no number; the forecaster's own chance of this, stated with the estimate: 25%; middle value at least 2.0-fold (0.30 log units) from the limit.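

Methyl in place of fluoro on this aromatic carbon, ortho to a large group, gives the first readable step in the series in this assay: an at least 2.1-fold higher number from compound 2 to compound 3 (0.32 log units; beyond the scatter). Compound 3 reads > 100000 nM, which is a limit of the assay and not a number. The step therefore fixes a direction and a minimum size only, and fluoro remains the only group shown at this position with a true number, so the room left for resolving further changes is narrow: the limit of > 100000 nM in this assay, at which 2 of the 3 values shown sit.

Going by these compounds, the true size of the step remains open, as does whether a chloro or a methoxy group on the same aromatic carbon would give a number or also sit at the limit. Also open, on these data alone, is whether an amine or a carboxylic acid at this position would give a number.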